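Hydroxy to Carboxy on the Ortho Position: Expected Solubility

The source may hold more compounds than are shown below. What is called first, only, known or untested is meant among the compounds shown, and "the series" means these compounds.

Three compounds sharing one core have been measured in a physicochemical assay for solubility, read by spectrophotometry, in phosphate buffer, with a stated time of 18 h, at pH 7.4; on this read-out higher numbers stand for higher solubility and lower numbers for lower solubility:
compound 1 , `CCc1ccc(-c2nc3c(c(C)nn3-c3ccccc3)c(-c3ccccc3O)c2C#N)cc1`, gives 3100 nM;
compound 2 , `CCc1ccc(-c2nc3c(c(C)nn3-c3ccccc3)c(-c3ccccc3C#N)c2C#N)cc1`, gives 2400 nM;
compound 3 , `CCc1ccc(-c2nc3c(c(C)nn3-c3ccccc3)c(-c3ccccc3S(C)(=O)=O)c2C#N)cc1`, gives 2200 nM.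

Compound 1 carries the top number of the three, but the margin is slim: a 1.3-fold lower number from compound 1 to compound 2 (0.11 log units; within the scatter) and a 1.4-fold lower number from compound 1 to compound 3 (0.15 log units; within the scatter), so the three sit together as far as this assay can tell. Between compound 2 and compound 3 the gap is smaller still, a 1.1-fold lower number from compound 2 to compound 3 (0.04 log units; within the scatter).

Compound 4 , `CCc1ccc(-c2nc3c(c(C)nn3-c3ccccc3)c(-c3ccccc3C(=O)O)c2C#N)cc1`, is the next step out from compound 1. The change is carboxy in place of hydroxy on an aromatic carbon. The two measured steps that bear on it are those already seen at the same aromatic carbon, where cyano and then methylsulfonyl each took the place of hydroxy and each left the number within the scatter. Within the data shown here, none of the three measured compounds carries a carboxy, so the new group has no direct precedent in this set. On that record the estimated step in this assay for compound 4 is a 1.1-fold higher number from compound 1 to compound 4 (0.05 log units; within the scatter), a move not expected to clear the scatter. The estimate for compound 4 is 3500 nM, with a range from 1500 nM to 9000 nM.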

Compound 4, solubility: 33000 nM
Estimate against measurement, compound 4: 9.4-fold (0.97 log units) below, outside the stated range (above it).
By their numbers in this assay, from the lowest: compounds 3, 2 and 1 (each within the scatter of the next); then compound 4.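

In this assay, the aromatic carbon ortho to a large group, where hydroxy, cyano and methylsulfonyl had given numbers within the scatter of one another, proves able to carry a much larger difference once carboxy stands there. The new group separates itself from all three earlier groups, with an 11-fold higher number from compound 1 to compound 4 (1.03 log units; beyond the scatter) and with a 14-fold higher number from compound 2 to compound 4 (1.14 log units; beyond the scatter) and also with a 15-fold higher number from compound 3 to compound 4 (1.18 log units; beyond the scatter), so compound 4 alone stands apart from a set that the assay could not otherwise divide. No measurement shown here accounts for the size of these steps.

The compounds shown leave open whether this jump belongs to the carboxylic acid alone or would also appear with a methyl ester, a primary amide, a tetrazole or an amine on the same carbon. They also leave open whether a longer chain ending in a carboxylic acid, such as carboxymethyl, or a carboxy group on another carbon of that ring would give a number nearer to compound 4 or to compound 1.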